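The source may report more compounds than this note shows. Statements on the series, on what has been measured and on what is new or still open speak of the compounds shown alone.

Compound 1 `COc1ccc(F)c(-c2ccc(C(=O)N(Cc3cccc(OCCCCCC(=O)O)c3)C(C)C)cc2)c1`: > 26000 nM in an ADME assay on HEK293 cells (Homo sapiens) for cytotoxicity, read by CellTiter-Glo and resazurin assay, with a stated time of 72 h; a higher number here means that more compound is needed for the effect, a lower number that less compound is needed.
Compound 2 `CC(C)N(Cc1cccc(OCCCCCC(=O)O)c1)C(=O)c1ccc(-c2cccc(Br)c2)cc1`: > 26000 nM.
Compound 3 `CCOC(=O)CCCCCOc1cccc(CN(C(=O)c2ccc(-c3cnc(OC)nc3OC)cc2)C(C)C)c1`: > 26000 nM.

Compound 3 stands at a limit of this assay, not at a measured number. Among the measured compounds shown here, the same is true of the other two compounds: all three sit at the limit of > 26000 nM in this assay, at which 3 of the 3 values shown sit, so no compound among the three can be set above or below another.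

Compound 4 `CCOC(=O)CCCCCOc1cccc(CN(C(=O)c2ccc(-c3cccc(-c4nnc(C)o4)c3)cc2)C(C)C)c1` differs from compound 3 at one place (3-(5-methyl-1,3,4-oxadiazol-2-yl)phenyl in place of 2,4-dimethoxypyrimidin-5-yl on an aromatic carbon). For the measured compounds named here, the only measured step between two compounds that differ in one place is the one from compound 1 to compound 2 a step that the two limits leave unreadable from compound 1 to compound 2, and since both of its ends are limits, its size cannot be read. Going by the values given here, no measured step therefore tells how large a change of this kind can be in this assay, in either direction.

With every value shown sitting at the limit, compound 4 is expected to sit there too, with an estimated step that the limit leaves unreadable from compound 3 to compound 4. The estimate for compound 4 is 40000 nM, expected to fall between 18000 nM and 120000 nM.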

Compound 4, half-maximal effective concentration: > 26000 nM
Compound 4 was reported as a limit; the forecaster's own chance of this, stated with the estimate: 80%; the middle value does not contradict the limit.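

No size can be given for the change from compound 3 to compound 4, since both are reported only as limits: the limit of > 26000 nM in this assay, at which 4 of the 4 values shown sit.

The compounds shown leave open how much of any of them is needed for the effect in this assay, and whether any of these structural changes alters that amount.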